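Cytotoxicity notes: an amide-acid chain replaces fluoro

This account rests on a few compounds, and the source may have more. Where it says the series, first, only, none or still open, it means among the compounds named here.

The series is followed in an ADME assay on MT4 cells (Homo sapiens) for cytotoxicity, read by MTT assay, with a stated time of 96 h; on this read-out lower numbers stand for higher toxicity in this test and higher numbers for lower toxicity in this test. Compound 1 `Fc1ccc(-c2nc3cc(C(F)(F)F)ccc3[nH]2)cc1` gives 22000 nM in this assay, the highest of the two plain numbers in hand. Its nearest neighbour, compound 2 `COc1ccc(-c2nc3cc(C(F)(F)F)ccc3[nH]2)c(N)c1`, gives 5000 nM; the gap between the two lies beyond the usual scatter, so compound 1 reads as the less toxic of the pair. Compound 3 `Cn1c(-c2ccc([N+](=O)[O-])cc2)nc2cc(C(F)(F)F)ccc21` returns >= 100000 nM; this is a limit of the test and not a number. Stated another way, one of the three values sits at the limit of >= 100000 nM in this assay, at which 1 of the 3 values shown sits.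

Compound 4 `O=C(O)CCC(=O)Nc1ccc(-c2nc3cc(C(F)(F)F)ccc3[nH]2)cc1` has not been measured. It is derived from compound 1 by ((2-carboxyethyl)carbonyl)amino in place of fluoro on an aromatic carbon. Among the compounds with values here, no pair of measured compounds differs in a single place, so no measured step gives the size of such a change here, and the direction must be set by expectation alone. The expectation for compound 4 in this assay is a move toward lower toxicity, that is a higher number, of a size beyond the scatter, with a real chance that only the ceiling of the test is reported. Compound 4 is thus expected near 60000 nM, between 20000 nM and 150000 nM. The expected step is a 2.7-fold higher number from compound 1 to compound 4 (0.44 log units; beyond the scatter).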

Compound 4, half-maximal cytotoxic concentration: > 100000 nM
Compound 4 gave a limit, no number; the forecaster's own chance of this, stated with the estimate: 40%; middle value at least 1.6-fold (0.22 log units) away from the limit.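

In this assay, within the data shown here, putting ((2-carboxyethyl)carbonyl)amino in place of fluoro on an aromatic carbon para to a large group gives an at least 4.5-fold higher number from compound 1 to compound 4 (0.65 log units; beyond the scatter), the first measured step that differs in a single place. Among these compounds, this sets the direction of the change at this position: the longer chain moves the read-out toward lower toxicity in this test, and the move lies beyond the scatter, which the earlier compounds, differing in more than one place, could not show. Compound 4 reads > 100000 nM, which is a limit and not a number, so the step gives a minimum size and its full size stays unknown: the limit of > 100000 nM in this assay, at which 1 of the 4 values shown sits.

The values do not tell whether the step belongs to the amide link or to the terminal carboxylic acid, and no cause for it can be assigned from them. An acetamide, which keeps the amide without the acid, and the methyl ester of the same chain at this position would separate those two parts, and a longer chain ending in the acid would test how far the change depends on chain length.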